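The compounds below may be only part of what the source reports. "The series", "measured", "known", "first", "only" and "open" are said of these compounds alone.

Measured compounds:
compound 1 `O=C(/C=C/c1cc(Br)ccc1O)c1ccc(Br)cc1` gives 28.3%
compound 2 `Cc1ccc(C(=O)/C=C/c2cc(Br)ccc2O)cc1` gives 31.8%
compound 3 `COc1cc(Br)cc2c1OC(N)=C(C#N)C2CC(=O)c1ccc(Br)cc1` gives 33.1%

All three were run in a functional assay on MCF7 cells (Homo sapiens) for antiproliferative activity, read by sulforhodamine B assay, with a stated time of 72 h, tested at 30 uM; on this read-out lower numbers stand for a stronger effect and higher numbers for a weaker effect at the one concentration tested. Compound 2 differs from compound 1 by methyl in place of bromo on an aromatic carbon, and the step is a number 3.5 percentage points higher from compound 1 to compound 2 (within the scatter), so compound 1 and compound 2 cannot be told apart on this read-out. Compound 3 sits close to both; its values against compound 1 and compound 2 show no separation either.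

Compound 4 `COc1cc(Br)cc2c1OC(N)=C(C#N)C2CC(=O)c1ccc(C)cc1` differs from compound 3 by methyl in place of bromo on an aromatic carbon. This is the same change as from compound 1 to compound 2, on the same place in both pairs, and it occurs twice among the compounds here. The difference between the core of compound 1 and the core of compound 3 is not broken down here.

The step from compound 3 to compound 4 is expected to be a number 2.9 percentage points higher from compound 3 to compound 4 (within the scatter), resting on compound 1 and compound 2, whose step a number 3.5 percentage points higher from compound 1 to compound 2 (within the scatter) stayed within the scatter. On this basis compound 4 is estimated at 36%, with a range from 25% to 47%.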

Compound 4, a percentage reported as activity, at one concentration (the size of the read-out at that concentration, not a potency): 52.8%
Compound 4: the middle estimate sits 16.8 percentage points below what was measured; measured number above the stated range.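

In this assay the change from 4-bromophenyl to 4-methylphenyl gives a number 19.7 percentage points higher from compound 3 to compound 4 (beyond the scatter) and so a weaker effect at the one concentration tested. The size of this change does not carry over intact from one core to the other: the same change on two cores in this assay, a number 3.5 percentage points higher (within the scatter) from compound 1 to compound 2 and a number 19.7 percentage points higher (beyond the scatter) from compound 3 to compound 4, 16.2 percentage points apart, beyond the scatter of two such steps. With one pair on each core and one concentration, this shows that the outcome of the change depends on the core in these two pairs, but it does not show which part of the core is responsible, what lies behind the difference, or how the change would behave on a further core.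

Still open, going by these compounds, is whether the sensitivity on the core of compound 3 is specific to methyl or extends to other groups in that place, such as chloro, methoxy, an amine or a carboxylic acid. Also open is whether the same two cores would part in this way with those groups, since only bromo and methyl are shown on each.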